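The compounds below may be only part of what the source reports. "The series", "measured", "known", "first", "only" and "open" are said of these compounds alone.

Going by the values given here, compound 1 `C#CCSc1cnc2ccccc2c1[Se]CC#CCCl` is the weaker of the two measured members. In a functional assay on CCRF-CEM cells (Homo sapiens) for antiproliferative activity, with a stated time of 72 h (on this read-out higher numbers stand for weaker inhibition and lower numbers for stronger inhibition), compound 1 gives 1.8 ug/mL, the highest of the two numbers in hand. Compound 2 `CSc1cnc2ccccc2c1[Se]CC#CCO`, which carries a hydroxyl at the end of its chain on selenium as well as a shorter chain on sulfur, gives 0.5 ug/mL, a lower number, and the gap between the two lies beyond the usual scatter. Compound 3 `OCC#CCSc1cnc2ccccc2c1[Se]CC#CCCl` keeps the whole framework of compound 1 and adds one change: hydroxymethyl in place of hydrogen on a triple-bonded carbon. No single-change step between measured compounds is available, so the size of the expected effect rests only on the two numbers shown. For compound 3 a modest move toward a lower number is expected, a 1.5-fold lower number from compound 1 to compound 3 (0.18 log units; within the scatter). Compound 3 is expected to give 1.2 ug/mL in this assay, within 0.5 ug/mL to 3 ug/mL.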

Compound 3, concentration for 50% inhibition: 2.6 ug/mL
For compound 3 the middle estimate is 2.2-fold (0.34 log units) below the measured one; low and high end bracket the measured number.
By their numbers in this assay, from the lowest: compound 2; then compounds 1 and 3 (each within the scatter of the next).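

In this assay, hydroxymethyl in place of hydrogen on a triple-bonded carbon gives a 1.4-fold higher number from compound 1 to compound 3 (0.16 log units; within the scatter), the first single-change step read in this series. At this position, the change from ethynyl to 3-hydroxyprop-1-yn-1-yl, which also reads as propargyl to 4-hydroxybut-2-yn-1-yl, is tolerated without a shift beyond the usual scatter. No available evidence bears on this result.

Going by these compounds, whether an amine, a carboxylic acid or a longer chain at this place would also stay within the scatter remains open. Going by these compounds alone, also open is how the chain on selenium, which ends in chlorine in both compound 1 and compound 3, affects the read-out, as no single-change step isolates that position.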